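Vinyl to dimethylamino on the shared core of compound 1

The source may hold more compounds than are shown below. What is called first, only, known or untested is meant among the compounds shown, and "the series" means these compounds.

Compound 1 `C=Cc1cccc(-c2[nH]c3cc(OC)ccc3c(=O)c2C(=O)OCC)c1` was tested in an ADME assay on Raji cells (Homo sapiens) for cytotoxicity, read by luminescence, with a stated time of 72 h; a higher number here means that more compound is needed for the effect, a lower number that less compound is needed. In this assay compound 1 gives > 21500 nM, which is a limit of the assay and not a number. Compound 2 `CCCOc1cccc(-c2[nH]c3cc(OC)ccc3c(=O)c2C(=O)OCC)c1` carries propoxy in place of vinyl on an aromatic carbon. In this assay compound 2 gives > 21500 nM, again a limit rather than a number. The step that the two limits leave unreadable from compound 1 to compound 2 is therefore of unreadable size, and the two values together sit at the limit of > 21500 nM in this assay, at which 2 of the 2 values shown sit.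

Compound 3 `CCOC(=O)c1c(-c2cccc(N(C)C)c2)[nH]c2cc(OC)ccc2c1=O` differs from compound 1 by dimethylamino in place of vinyl on an aromatic carbon. Going by the values given here, the only measured step that touches this position, a step that the two limits leave unreadable from compound 1 to compound 2, has a size the two limits leave unreadable, so neither a direction nor a size can be taken from it. Among the compounds with values here, nothing in the two values measured so far points toward the readable range, and compound 3 is expected to sit at the limit as well, with an estimated step that the limit leaves unreadable from compound 1 to compound 3. The estimate for compound 3 is 30000 nM, within a range from 10000 nM to 100000 nM.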

Compound 3, half-maximal effective concentration: > 21500 nM
Compound 3 ended at the assay's limit (the forecaster's own chance of this, stated with the estimate: 80%); the middle value is on the limit's open side.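

In this assay compound 3 gives > 21500 nM, which is a limit of the assay and not a number. Going by these compounds alone, no step among compound 1, compound 2 and compound 3 can therefore be read. The compounds shown leave open whether any group at this place on the shared core brings the half-maximal effective concentration into the readable range, and all the values rest at one point: the limit of > 21500 nM in this assay, at which 3 of the 3 values shown sit.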